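A Methoxycyclohexylmethyl Replacement for a Hydroxycyclobutyl Group

The compounds below may be only part of what the source reports. "The series", "measured", "known", "first", "only" and "open" are said of these compounds alone.

Three compounds share one core. Compound 1 `N#Cc1cnc(NCc2cnccc2C(F)(F)F)cc1N[C@H]1C[C@@H](O)C1` gives 500 nM in an assay on isolated protein for inhibition of protein kinase C theta type (Homo sapiens), read by TR-FRET, with a stated time of 2 h (on this read-out lower numbers stand for stronger inhibition and higher numbers for weaker inhibition), compound 2 `N#Cc1cnc(NCc2cnccc2C(F)(F)F)cc1N[C@H]1C[C@H](O)C1` gives 900 nM, and compound 3 `N#Cc1cnc(NCc2cnccc2C(F)(F)F)cc1N[C@H]1CC[C@H](O)CC1` gives 350 nM. Compound 2 is separated from compound 3 by a 2.6-fold lower number from compound 2 to compound 3 (0.41 log units; beyond the scatter), whereas a 1.8-fold higher number from compound 1 to compound 2 (0.26 log units; within the scatter) stays within the scatter, a pair that differ only in configuration (the fact that compounds 1 and 2 differ only in the configuration as drawn). Compound 4 `CO[C@H]1CC[C@H](CNc2cc(NCc3cnccc3C(F)(F)F)ncc2C#N)CC1` carries the change ((4-methoxycyclohexyl)methyl in place of 3-hydroxycyclobutyl on a nitrogen on an aromatic ring). The nearest measured steps are a 2.6-fold lower number from compound 2 to compound 3 (0.41 log units; beyond the scatter) and a 1.4-fold lower number from compound 1 to compound 3 (0.15 log units; within the scatter), both moving toward lower numbers when a six-membered ring replaces the four-membered one. Going by the values given here, the methylene spacer and methoxy group have no measured counterpart here, so the expected step is a 1.5-fold lower number from compound 2 to compound 4 (0.18 log units; within the scatter), with wide uncertainty. Compound 4 is therefore estimated at 600 nM, between 150 nM and 2500 nM.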

Compound 4, half-maximal inhibitory concentration: 330 nM
The estimate for compound 4 lay 1.8-fold (0.26 log units) above the measured number; the measured number falls inside the stated range.
By their numbers in this assay, from the lowest: compounds 4, 3, 1 and 2 (each within the scatter of the next, the first and the last beyond it).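

Against the 4-hydroxycyclohexyl group, the (4-methoxycyclohexyl)methyl group shows a 1.1-fold lower number from compound 3 to compound 4 (0.03 log units; within the scatter), so a group with 0 hydrogen-bond donors reads level with a hydroxylated one on this nitrogen. Against 3-hydroxycyclobutyl, the same change shows a 2.7-fold lower number from compound 2 to compound 4 (0.44 log units; beyond the scatter) but only a 1.5-fold lower number from compound 1 to compound 4 (0.18 log units; within the scatter), so whether it stands out depends on which drawn configuration it is read from. Nothing measured here accounts for these steps. The compounds shown leave open what the methoxy group and the spacer each contribute alone, and how a (4-hydroxycyclohexyl)methyl or 4-aminocyclohexyl group would read.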